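The compounds below may be only part of what the source reports. "The series", "measured", "known", "first", "only" and "open" are said of these compounds alone.

In a functional assay on HepG2 cells (Homo sapiens) for antiproliferative activity, read by MTT assay, with a stated time of 72 h (a lower number here means a stronger inhibitor, a higher number a weaker inhibitor), three compounds sharing one core differ in the group on an amide-type nitrogen in a ring. Compound 1 `COc1cccc(N2C(=O)COc3ccc(-c4cnc5ccccc5c4)cc32)c1`, carrying 3-methoxyphenyl, gives 2080 nM. Compound 2 `O=C1COc2ccc(-c3cnc4ccccc4c3)cc2N1C1CCCCC1`, carrying cyclohexyl, gives > 40000 nM, which is a limit of the assay and not a number. Compound 3 `Cc1ccc(N2C(=O)COc3ccc(-c4cnc5ccccc5c4)cc32)cc1`, carrying 4-methylphenyl, gives > 40000 nM, which is also a limit. Compound 3 therefore stands at the limit of > 40000 nM in this assay, at which 2 of the 3 values shown sit.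

Compound 4 `COc1ccc(N2C(=O)COc3ccc(-c4cnc5ccccc5c4)cc32)cc1` changes compound 3 in one place, with methoxy in place of methyl on an aromatic carbon, para to a large group: methoxy in place of methyl on an aromatic carbon. The nearest measured evidence is an at least 19-fold higher number from compound 1 to compound 3 (1.28 log units; beyond the scatter), a large step beyond the scatter. The change to cyclohexyl gives a similar picture, an at least 19-fold higher number from compound 1 to compound 2 (1.28 log units; beyond the scatter), also large. The step that the two limits leave unreadable from compound 2 to compound 3 says nothing further. For the measured compounds named here, the only true number so far belongs to compound 1, at 2080 nM, and that compound carries a methoxy group, though not in the position it takes in compound 4. Going by the values given here, no measured pair isolates the swap of methyl for methoxy, so the expectation is loose: a lower number than the limit of compound 3, possibly a large step, though compound 4 could also stay at the limit. The expected move is an at least 3.3-fold lower number from compound 3 to compound 4 (0.52 log units; beyond the scatter). Compound 4 is estimated at 12000 nM, with an expected range of 2000 nM to 40000 nM.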

Compound 4, half-maximal inhibitory concentration: > 40000 nM
Compound 4 gave a limit, no number; the forecaster's own chance of this, stated with the estimate: 40%; at least 3.3-fold (0.52 log units) between middle value and limit.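

In this assay, 4-methoxyphenyl in place of 3-methoxyphenyl on the amide-type nitrogen gives an at least 19-fold higher number from compound 1 to compound 4 (1.28 log units; beyond the scatter), so among these compounds, a methoxy group on the phenyl ring is not enough to match compound 1; where it sits matters. From the compounds shown here alone, the steps from compound 3 to compound 4 and from compound 2 to compound 4 join two limits and cannot be read, so methoxy in place of methyl brings no change that can be seen here, and any difference hidden past the limit stays unknown. Compound 1 remains the only compound shown with a true number, and the other three share one limit: the limit of > 40000 nM in this assay, at which 3 of the 4 values shown sit.

Going by these compounds, what stays open is whether the number of compound 1 depends on the methoxy group itself or whether another group in its place, such as 3-methylphenyl, 3-chlorophenyl or 3-aminophenyl, would give a readable value. An unsubstituted phenyl group on the same nitrogen would also show whether the methoxy group of compound 1 adds anything to the ring alone.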